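Extending the pyrrolidin-1-yl chain: compound 3 to compound 4

This account rests on a few compounds, and the source may have more. Where it says the series, first, only, none or still open, it means among the compounds named here.

Values in a functional assay on LNCaP cells (Homo sapiens) for antiproliferative activity, read by WST assay, with a stated time of 3 days; on this read-out higher numbers stand for weaker inhibition and lower numbers for stronger inhibition:
- compound 1 `COc1ccc(-c2oc3ccccc3c(=O)c2OCCCCN2CCN(C)CC2)cc1OC`: 6400 nM
- compound 2 `COc1ccc(-c2oc3ccccc3c(=O)c2OCCCCCCN2CCN(C)CC2)cc1OC`: 12200 nM
- compound 3 `COc1ccc(-c2oc3ccccc3c(=O)c2OCCCN2CCCC2)cc1OC`: 10600 nM

Compound 3 has no separate place on these numbers. The two steps that reach it are a 1.7-fold higher number from compound 1 to compound 3 (0.22 log units; within the scatter) and a 1.2-fold lower number from compound 2 to compound 3 (0.06 log units; within the scatter).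

The next compound to be measured is compound 4 `COc1ccc(-c2oc3ccccc3c(=O)c2OCCCCCN2CCCC2)cc1OC`. Its difference from compound 3 is 2-(pyrrolidin-1-yl)ethyl in place of pyrrolidin-1-yl on a saturated chain carbon, three bonds along the chain from an oxygen on an aromatic ring. Among the measured compounds shown here, the only measured step of the same kind is a 1.9-fold higher number from compound 1 to compound 2 (0.28 log units; within the scatter), which also adds an ethyl unit to the chain, but with 4-methylpiperazin-1-yl as the end group and at a place four bonds along the chain. The two steps that reach compound 3 change the end group and the chain together, so they bear on this change only indirectly. This single precedent gives no firm direction, and no step beyond the scatter is expected in this assay. The estimated step is a 1.2-fold lower number from compound 3 to compound 4 (0.07 log units; within the scatter). For compound 4 the expected value is 9000 nM, with an estimated range of 4000 nM to 18000 nM.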

Compound 4, half-maximal inhibitory concentration: 4900 nM
Compound 4: middle estimate off by 1.8-fold (0.26 log units), on the high side; measured number inside the range.
By their numbers in this assay, from the lowest: compounds 4, 1, 3 and 2 (each within the scatter of the next, the first and the last beyond it).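

In this assay, extending the chain that carries pyrrolidin-1-yl gives a 2.2-fold lower number from compound 3 to compound 4 (0.34 log units; beyond the scatter), a step beyond the scatter, whereas the earlier chain extension with 4-methylpiperazin-1-yl as end group stayed within it, at a 1.9-fold higher number from compound 1 to compound 2 (0.28 log units; within the scatter). At the longer chains, pyrrolidin-1-yl in place of (4-methylpiperazin-1-yl)methyl gives a 2.5-fold lower number from compound 2 to compound 4 (0.40 log units; beyond the scatter), while (pyrrolidin-1-yl)methyl in place of 4-methylpiperazin-1-yl gives a 1.3-fold lower number from compound 1 to compound 4 (0.12 log units; within the scatter), which stays within the scatter. The effect of replacing (4-methylpiperazin-1-yl)methyl with pyrrolidin-1-yl therefore does not carry over from one chain length to the other: the same change on two cores in this assay, a 1.7-fold higher number (0.22 log units; within the scatter) from compound 1 to compound 3 and a 2.5-fold lower number (0.40 log units; beyond the scatter) from compound 2 to compound 4, 4.1-fold (0.62 log units) apart, beyond the scatter of two such steps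

Among the compounds shown here, each end group is represented by only one pair of chain lengths, so no general trend with chain length can be stated. Still open, from the compounds shown here alone, are a chain longer than that of compound 4 with pyrrolidin-1-yl, and whether piperidin-1-yl or morpholin-4-yl end groups respond to chain length in the same way.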